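Moving a Chlorine Around a Dichlorophenyl Group

This account rests on a few compounds, and the source may have more. Where it says the series, first, only, none or still open, it means among the compounds named here.

compound 1 `Cc1ccc(N(C(=O)c2ccc([N+](=O)[O-])cc2)C(=S)OCCN2C(=O)c3ccccc3C2=O)cc1` gives 58000 nM
compound 2 `Cc1ccc(N(C(=O)c2c(F)cccc2F)C(=S)OCCN2C(=O)c3ccccc3C2=O)cc1` gives 65000 nM
compound 3 `Cc1ccc(N(C(=O)c2cccc(Cl)c2Cl)C(=S)OCCN2C(=O)c3ccccc3C2=O)cc1` gives 35000 nM

These three compounds were measured in an ADME assay on MT4 cells (Homo sapiens) for cytotoxicity, read by MTT assay (a higher number here means that more compound is tolerated, a lower number that less compound is tolerated), and differ only in the group on a carbonyl carbon. Compound 3 cannot be told apart from the other two, as the steps show: a 1.7-fold lower number from compound 1 to compound 3 (0.22 log units; within the scatter) and a 1.9-fold lower number from compound 2 to compound 3 (0.27 log units; within the scatter). The third step at this place, a 1.1-fold higher number from compound 1 to compound 2 (0.05 log units; within the scatter), also stays within the scatter.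

Compound 4 `Cc1ccc(N(C(=O)c2ccc(Cl)cc2Cl)C(=S)OCCN2C(=O)c3ccccc3C2=O)cc1` has not been measured yet. It has 2,4-dichlorophenyl in place of the 2,3-dichlorophenyl of compound 3 on a carbonyl carbon (2,4-dichlorophenyl in place of 2,3-dichlorophenyl on a carbonyl carbon). The two compounds therefore have the same atoms, joined differently.

Going by the values given here, no measured step makes this exact change, so the evidence is indirect. The three measured steps each exchange one whole group at this same place, and none goes beyond the scatter. Since a 1.9-fold lower number from compound 2 to compound 3 (0.27 log units; within the scatter) is one such exchange, no step beyond the scatter is expected in this assay, in either direction. The expected step is a 1.2-fold higher number from compound 3 to compound 4 (0.08 log units; within the scatter), which would be no real change. For compound 4 the estimated value is 42000 nM, with an expected range from 22000 nM to 75000 nM.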

Compound 4, half-maximal cytotoxic concentration: 49000 nM
The estimate for compound 4 lay 1.2-fold (0.07 log units) below the measured number; the measured number falls inside the stated range.
By their numbers in this assay, from the lowest: compounds 3, 4, 1 and 2 (each within the scatter of the next).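

Moving one chlorine, so that 2,4-dichlorophenyl replaces 2,3-dichlorophenyl on a carbonyl carbon, is the smallest exchange at this place so far, keeping the same atoms and joining them differently, and in this assay it gives a 1.4-fold higher number from compound 3 to compound 4 (0.15 log units; within the scatter). The new compound also stays close to the two groups of a different kind, with a 1.3-fold lower number from compound 2 to compound 4 (0.12 log units; within the scatter) and a 1.2-fold lower number from compound 1 to compound 4 (0.07 log units; within the scatter), so all four compounds now sit within the scatter of one another in this assay, and neither a swap of the whole group nor a shift of one chlorine separates them. Nothing measured here bears on why these four compounds read alike.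

On these data alone, all four groups at this place are substituted phenyl rings, so it remains open whether something of another kind, such as a ring carrying an amine or a carboxylic acid, or a longer alkyl chain, would take the number beyond the scatter. These compounds also share the rest of their structure, so they cannot show whether a chlorine shift would be just as silent on a different core.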